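The source may hold more compounds than are shown below. What is called first, only, known or untested is meant among the compounds shown, and "the series" means these compounds.

Compound 1 `Cc1cc(SC(C)(C)C)c(S(C)(=O)=O)cc1C(=O)N=C(N)N`: 22 nM
Compound 2 `Cc1cc(OC2CCCC2)c(S(C)(=O)=O)cc1C(=O)N=C(N)N`: 27 nM

In a functional assay for inhibition of sodium/hydrogen exchanger (Oryctolagus cuniculus) (on this read-out higher numbers stand for weaker inhibition and lower numbers for stronger inhibition), compound 2 gives 27 nM, the highest of the two numbers measured; compound 1 gives 22 nM, and the step of a 1.2-fold higher number from compound 1 to compound 2 (0.09 log units; within the scatter) lies within the scatter. Compound 3 `Cc1cc(-n2ccnc2C)c(S(C)(=O)=O)cc1C(=O)N=C(N)N` is not yet measured. Its change from compound 2: 2-methyl-1H-imidazol-1-yl in place of cyclopentyloxy on an aromatic carbon. Within the data shown here, the only measured step, a 1.2-fold higher number from compound 1 to compound 2 (0.09 log units; within the scatter), exchanged a group at this same place without a change beyond the scatter. Among the measured compounds shown here, no measured step involves an aromatic ring here, so a step beyond the scatter is not expected for compound 3, whose estimated step is a 1.3-fold higher number from compound 2 to compound 3 (0.11 log units; within the scatter). Compound 3 is thus expected at 35 nM, with a range from 10 nM to 120 nM.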

Compound 3, half-maximal inhibitory concentration: 29 nM
Estimate against measurement, compound 3: 1.2-fold (0.08 log units) above, and the stated range covers the measured number.
By their numbers in this assay, from the lowest: compounds 1, 2 and 3 (each within the scatter of the next).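

The position ortho to the methylsulfonyl group carries an aromatic ring here, 2-methyl-1H-imidazol-1-yl, and in this assay this exchange stays within the scatter of both earlier groups (a 1.1-fold higher number from compound 2 to compound 3 (0.03 log units; within the scatter); a 1.3-fold higher number from compound 1 to compound 3 (0.12 log units; within the scatter)). Across these three compounds, cyclopentyloxy, (tert-butyl)sulfanyl and this aromatic ring therefore read alike. Nothing available explains this sameness.

Going by these compounds, whether an amine, a carboxylic acid or a longer chain at this place would also stay within the scatter remains open. So does the effect of the imidazole ring without its methyl group.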